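The compounds below may be only part of what the source reports. "The series", "measured", "known", "first", "only" and "open" are said of these compounds alone.

Of the compounds shown here, two have numbers so far in a functional assay on HCT-116 cells (Homo sapiens) for inhibition, read by MTT assay, with a stated time of 72 h; on this read-out higher numbers stand for weaker inhibition and lower numbers for stronger inhibition. Compound 1 (`COc1cc(Oc2cccc(Nc3ccccc3)c2)cc(OC)c1CNCCNC(C)=O`) gives 18200 nM, and compound 2 (`COc1cc(Oc2cccc(Nc3ccccc3)c2)cc(OC)c1CNCc1ccc(Cl)cc1`) gives 3310 nM, the lower of the two numbers. Next in line is compound 3 (`COc1cc(Oc2cccc(Nc3ccccc3)c2)cc(OC)c1CCO`), which differs from compound 2 as follows: hydroxymethyl in place of (4-chlorobenzyl)amino on a saturated chain carbon bound to an aromatic carbon. In words, hydroxymethyl stands in place of (4-chlorobenzyl)amino on a saturated chain carbon bound to an aromatic carbon.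

Among the compounds with values here, no measured step covers this exchange directly. Within the data shown here, the only measured step is a 5.5-fold lower number from compound 1 to compound 2 (0.74 log units; beyond the scatter), modest and beyond the scatter, with 4-chlorophenyl in place of acetamidomethyl on a saturated chain carbon bound to an amine nitrogen. It offers a loose guide, since compound 3, like compound 1 at 18200 nM, lacks the 4-chlorophenyl ring of compound 2. Among the measured compounds shown here, a modest move to a higher number in this assay is therefore expected, probably no larger than that step, although one example gives weak support. The expected change is a 2.7-fold higher number from compound 2 to compound 3 (0.43 log units; beyond the scatter). For compound 3 the estimated value is 9000 nM, with an expected range of 2500 nM to 30000 nM.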

Compound 3, half-maximal inhibitory concentration: > 20000 nM
Compound 3 gave a limit, no number; the forecaster's own chance of this, stated with the estimate: 10%; at least 2.2-fold (0.34 log units) between middle value and limit.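

The reading for compound 3 in this assay is a limit of the assay and not a number: the limit of > 20000 nM in this assay, at which 1 of the 3 values shown sits.

Within the data shown here, exchanging (4-chlorobenzyl)amino for hydroxymethyl, on a saturated chain carbon bound to an aromatic carbon, gives an at least 6.0-fold higher number from compound 2 to compound 3 (0.78 log units; beyond the scatter); together with a 5.5-fold lower number from compound 1 to compound 2 (0.74 log units; beyond the scatter), this makes compound 2, the only one of the three carrying the 4-chlorophenyl ring, the one with the lowest number. The comparison with the other compound lacking that ring gives an at least 1.0-fold higher number from compound 1 to compound 3 (0.04 log units; that floor lies within the scatter), and since that floor lies within the scatter, no order can be stated between them.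

The single exchange from compound 2 to compound 3 removes the amine nitrogen and the 4-chlorophenyl ring together, so the compounds shown do not say which of the two carries the difference, and how far compound 3 lies past its limit also stays open. A plain benzylamino group without the chlorine, or a 4-chlorobenzyl ether in place of the amine, would bear on the first of these questions.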